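One Methyl Removed: What to Expect for Compound 4

This account rests on a few compounds, and the source may have more. Where it says the series, first, only, none or still open, it means among the compounds named here.

Measured so far in a functional assay on BGC-823 cells (Homo sapiens) for inhibition, read by sulforhodamine B assay, with a stated time of 48 h, tested at 10 uM; a lower number here means less inhibition of growth, a higher number more inhibition of growth at the concentration tested:
- compound 1, `O=C(N/N=C/c1ccccc1O)c1ccc(-c2ccc(F)cc2)o1`, gives 74%
- compound 2, `O=C(N/N=C/c1ccc(-c2ccc(F)cc2F)o1)c1ccccc1O`, gives 68.4%
- compound 3, `COc1ccccc1/C=N/NC(=O)c1ccc(-c2ccc(F)cc2F)o1`, gives 66.8%

Compound 3 has the lowest of the three numbers, yet the gap to compound 2 and the gap to compound 1 both lie within the scatter of repeated measurements, so the three compounds cannot be told apart on these numbers.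

The step to compound 4, `O=C(N/N=C/c1ccccc1O)c1ccc(-c2ccc(F)cc2F)o1`, is a small one: hydrogen in place of methyl on an oxygen on an aromatic ring. In compound 3 the oxygen on the aromatic ring carries a methyl; in compound 4 it carries a hydrogen, so a methoxy group becomes a hydroxy group. Compound 1 already carries a hydroxy group on its aromatic ring and gives 74%, a number within the scatter of compound 3.

Among the measured compounds shown here, no step between two measured compounds isolates this change, so the expectation rests on the closeness of the three numbers. In this assay the expected step is a number 3.2 percentage points higher from compound 3 to compound 4 (within the scatter), that is, none beyond the scatter. Compound 4 is therefore estimated at 70%, with a likely range from 55% to 82%.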

Compound 4, percent growth inhibition at one concentration: 79.1%
For compound 4 the middle estimate is 9.1 percentage points below the measured one, within the range that was stated.
By their numbers in this assay, from the lowest: compounds 3, 2, 1 and 4 (each within the scatter of the next, the first and the last beyond it).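

Among the compounds shown here, replacing the methyl on this oxygen with hydrogen gives a number 12.3 percentage points higher from compound 3 to compound 4 (beyond the scatter) in this assay, the first step in this set that isolates this change, and it shows that the methoxy and hydroxy forms can be told apart here. Fluoro in place of hydrogen on an aromatic carbon gives a number 5.1 percentage points higher from compound 1 to compound 4 (within the scatter), so that second change has no effect that can be separated from ordinary variation between repeat measurements. Nothing available explains why the change from methoxy to hydroxy shifts the growth inhibition.

On these data alone, it remains open whether an ethyl group on the same oxygen, or an amine in place of the hydroxy group, would give a number closer to compound 3 or to compound 4. The compounds shown also leave open whether the step from methoxy to hydroxy would hold on other cell lines or at other concentrations.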